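Chloro-to-hydrogen step on a fused bichloro core

This account rests on a few compounds, and the source may have more. Where it says the series, first, only, none or still open, it means among the compounds named here.

Three compounds have been run in a functional assay on 786-0 cells (Homo sapiens) for cytotoxicity, read by sulforhodamine B assay, with a stated time of 48 h; a higher number here means a weaker inhibitor of growth, a lower number a stronger inhibitor of growth. Compound 1 `ClCc1ccc(Cn2cnc3c(Cl)ncnc32)cc1` gives 3980 nM, compound 2 `ClCc1ccc(Cn2cnc3nc(Cl)nc(Cl)c32)cc1` gives 3710 nM, and compound 3 `ClCc1ccc(Cn2cnc3c(Cl)nc(Cl)nc32)cc1` gives 29500 nM. Compound 2 and compound 1 sit within the scatter of each other; compound 3 stands apart from both. The difference between the cores of compound 2 and compound 3 is not broken down here. The change hydrogen in place of chloro on an aromatic carbon gave a 7.4-fold lower number from compound 3 to compound 1 (0.87 log units; beyond the scatter). Compound 4 `ClCc1ccc(Cn2cnc3ncnc(Cl)c32)cc1` carries the same change from compound 2, (hydrogen in place of chloro on an aromatic carbon), and the surroundings of the place are the same in both cases. For the measured compounds named here, only one instance of the step is known. Because compound 1 gives 3980 nM while also bearing one chloro group, a smaller gain is expected than the earlier step: the estimated step is a 2.5-fold lower number from compound 2 to compound 4 (0.39 log units; beyond the scatter). Compound 4 is expected to give about 1500 nM, between 400 nM and 6000 nM.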

Compound 4, concentration for total growth inhibition: 3010 nM
The estimate for compound 4 lay 2.0-fold (0.30 log units) below the measured number, within the range that was stated.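

In this assay, hydrogen in place of chloro on the aromatic carbon between two ring nitrogen atoms gave a 1.2-fold lower number from compound 2 to compound 4 (0.09 log units; within the scatter), so the size of the step did not carry over from one core to the other: the same change on two cores in this assay, a 7.4-fold lower number (0.87 log units; beyond the scatter) from compound 3 to compound 1 and a 1.2-fold lower number (0.09 log units; within the scatter) from compound 2 to compound 4, 6.0-fold (0.78 log units) apart, beyond the scatter of two such steps

The change therefore cannot be treated as a fixed increment across these two cores. For the compounds shown here, with only one pair on each core, this does not show how the step would behave on any further core, nor why the two steps differ.

Still open, as far as these compounds go, is whether an amine or a methoxy group in that place would give steps that differ between the cores in the same way. Also open, from the compounds shown here alone, is how either core responds when the chloromethyl group gives way to a hydroxymethyl group.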